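The source may report more compounds than this note shows. Statements on the series, on what has been measured and on what is new or still open speak of the compounds shown alone.

Measured compounds:
Compound 1 `CCCc1nc(C)c2c(C)nn(CC)c(=O)n12` gives > 48000 nM, a limit of the assay rather than a number.
Compound 2 `CC(C)CCSc1nncc2cncn12` gives 9000 nM.
Compound 3 `CCCc1nc(C)c2cnnc(O)n12` gives 56800 nM.

The read-out behind these figures is a functional assay for inhibition, with Homo sapiens as the target; on this read-out lower numbers stand for stronger inhibition and higher numbers for weaker inhibition. Among the two numbers obtained, compound 2 has the lowest; its nearest neighbour is compound 3, whose value sits higher than that of compound 2 by a margin beyond the usual scatter. Compound 1 contributes no number, only (the limit of > 48000 nM in this assay, at which 1 of the 3 values shown sits).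

The next compound, compound 4 `Sc1nncc2cncn12`, differs from compound 2 in one place: hydrogen in place of isopentyl on a sulfur. Within the data shown here, no pair of measured compounds separates by a change of this kind, so there is no measured step to lean on. Since compound 2 holds the lowest number seen, a change that strips away the isopentyl leaves little precedent, and a move toward a higher number in this assay is the more cautious expectation, with a real chance that only a limit is reported.

Compound 4 is expected to give 40000 nM, within a range from 10000 nM to 160000 nM. That estimate implies an expected step of a 4.4-fold higher number from compound 2 to compound 4 (0.65 log units; beyond the scatter) toward weaker inhibition.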

Compound 4, half-maximal inhibitory concentration: > 48000 nM
Compound 4: a limit, no number (the forecaster's own chance of this, stated with the estimate: 40%); middle value at least 1.2-fold (0.07 log units) from the limit.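

Taking the isopentyl off the sulfur and leaving hydrogen in its place gives an at least 5.3-fold higher number from compound 2 to compound 4 (0.72 log units; beyond the scatter) in this assay. Among these compounds, this is the first step that can be read at a single place, since no earlier pair of compounds differed in one place only. It shows that the measurable inhibition of compound 2 is lost to the limit of the assay once this sulfur carries only hydrogen, yet only the lower end of the step is known, since compound 4 gives a limit and not a number: the limit of > 48000 nM in this assay, at which 2 of the 4 values shown sit.

The compounds shown leave open whether the full isopentyl is needed, or whether a methyl group, a longer chain or a benzyl group on the same sulfur would give a lower or a higher number in this assay. They also leave open whether the sulfur itself matters, which an amine or an ether oxygen carrying the same isopentyl in its place would test.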